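A few compounds are considered here, and "the series" means these few. Any claim that something is new, unique, unknown or untested is made for them only; others in the source may bear on it.

Measured so far in a functional assay on MCF7 cells (Homo sapiens) for antiproliferative activity, read by sulforhodamine B assay, with a stated time of 72 h, tested at 30 uM; a higher number here means a weaker effect of the compound at the concentration tested, a lower number a stronger effect:

compound 1 `COc1cc(Br)cc(/C=C/C(=O)c2ccc(C)cc2)c1O` gives 61.5%
compound 2 `COc1cc(Br)cc(/C=C/C(=O)c2ccc(Br)cc2)c1O` gives 48.3%
compound 3 `COc1cc(Br)cc2c1OC(N)=C(C#N)C2CC(=O)c1ccc(Br)cc1` gives 33.1%

Compound 3 stands lowest of the three in this assay, with its steps to compound 2 and compound 1 beyond the scatter. Compound 1 and compound 2 share one core; compound 3 carries a different core, and the difference between the two cores is not broken down here. Within the first core, the change from compound 2 to compound 1, (methyl in place of bromo on an aromatic carbon), gave a number 13.2 percentage points higher from compound 2 to compound 1 (beyond the scatter).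

Compound 4 `COc1cc(Br)cc2c1OC(N)=C(C#N)C2CC(=O)c1ccc(C)cc1` is not yet measured. It differs from compound 3 by methyl in place of bromo on an aromatic carbon, the same change as from compound 2 to compound 1, at the same place. Within the data shown here, for compound 4 in this assay a step of a number 12.9 percentage points higher from compound 3 to compound 4 (beyond the scatter) is expected, resting on the one measured instance of this change, a number 13.2 percentage points higher from compound 2 to compound 1 (beyond the scatter), since a single pair on a different core can only be a rough guide. The estimate for compound 4 is 46%, expected to fall between 33% and 60%.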

Compound 4, a percentage reported as activity, at one concentration (the size of the read-out at that concentration, not a potency): 52.8%
Beside the measured number, compound 4's estimate is 6.8 percentage points below it; measured number inside the range.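

In this assay the change from 4-bromophenyl to 4-methylphenyl on the core of compound 3 gave a number 19.7 percentage points higher from compound 3 to compound 4 (beyond the scatter) as the new step. The change carries from one core to the other in direction, and the two steps do not differ in size: the same change on two cores in this assay, a number 13.2 percentage points higher (beyond the scatter) from compound 2 to compound 1 and a number 19.7 percentage points higher (beyond the scatter) from compound 3 to compound 4, 6.5 percentage points apart, within the scatter of two such steps. Among these compounds, this rests on only two pairs, a single change at one place and one concentration, so it shows neither that the step would hold on further cores nor how the two cores differ in themselves.

The compounds shown leave open whether chloro or methoxy at this place would follow the same course on both cores. The same holds for an amine or a carboxylic acid there.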